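The source may hold more compounds than are shown below. What is called first, only, known or untested is meant among the compounds shown, and "the series" means these compounds.

Measured so far:
compound 1 `OCCCNc1ncnc2[nH]cc(-c3cccc(Cl)c3)c12`: 552 nM
compound 2 `CC(=O)NC1CCN(c2ncnc3[nH]cc(-c4cccc(Cl)c4)c23)CC1`: 122 nM
compound 3 `CNC1CCN(c2ncnc3[nH]cc(-c4cccc(Cl)c4)c23)CC1`: 408 nM

In an assay on HEK293T cells for displacement of a labelled ligand from serine/threonine-protein kinase 4 (Homo sapiens), read by NanoBRET, with a stated time of 2 h (a lower number here means a stronger inhibitor, a higher number a weaker inhibitor), compound 2 gives the lowest number of the three, with compound 3 next and compound 1 furthest off. Compound 4 `Clc1cccc(-c2c[nH]c3ncnc(N4CCCCC4)c23)c1` is not yet measured; against compound 2 it shows (hydrogen in place of acetamido on a saturated ring carbon). The step that bears most on this change is a 3.3-fold higher number from compound 2 to compound 3 (0.52 log units; beyond the scatter), where paring acetyl to methyl already cost ground; compound 4 removes the group altogether. The step of a 1.4-fold lower number from compound 1 to compound 3 (0.13 log units; within the scatter) shows little separation elsewhere. A further rise in the number is therefore expected, perhaps larger than for compound 3. Compound 4 is estimated at 600 nM, in the range 250 nM to 1500 nM, which means an expected step of a 4.9-fold higher number from compound 2 to compound 4 (0.69 log units; beyond the scatter).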

Compound 4, half-maximal inhibitory concentration: 549 nM
Compound 4: the middle estimate sits 1.1-fold (0.04 log units) above what was measured, and the stated range covers the measured number.
By their numbers in this assay, from the lowest: compound 2; then compounds 3, 4 and 1 (each within the scatter of the next).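

Taking the acetamido group off the saturated ring carbon gives a 4.5-fold higher number from compound 2 to compound 4 (0.65 log units; beyond the scatter), whereas hydrogen in place of methylamino at that carbon gives only a 1.3-fold higher number from compound 3 to compound 4 (0.13 log units; within the scatter), so of the groups shown, only acetamido stands apart from the bare ring. Piperidin-1-yl in place of (3-hydroxypropyl)amino on the aromatic carbon gives a 1.0-fold lower number from compound 1 to compound 4 (0.00 log units; within the scatter), so these two groups cannot be told apart here. Nothing on hand explains why acetamido stands apart. Going by these compounds, whether a urea or a methanesulfonamide on that ring carbon would match acetamido remains open.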